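Swapping a Piperazine Ring for a Pyrrolidine at One Chain End

The source may hold more compounds than are shown below. What is called first, only, known or untested is meant among the compounds shown, and "the series" means these compounds.

Measured compounds, in an assay on HEK293 cells for agonist activity at Toll-like receptor 8 (Homo sapiens), read by spectrophotometry; on this read-out higher numbers stand for an effect only at larger amounts of compound and lower numbers for an effect already at smaller amounts:
Compound 1 `CCCCNc1nc(N)nc(C)c1CCCN1CCN(C)CC1`: 179 nM
Compound 2 `CCCCNc1nc(N)nc(C)c1CCC(C)(C)O`: 3140 nM
Compound 3 `CCCCNc1nc(N)nc(C)c1CCCCCc1ccccc1`: 830 nM

Compound 1 stands lowest of the three numbers, meaning its effect appears at the smallest amount of compound. Its nearest neighbour is compound 3 with a 4.6-fold higher number from compound 1 to compound 3 (0.67 log units; beyond the scatter), and compound 2 lies furthest away with an even higher number.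

Compound 4 `CCCCNc1nc(N)nc(C)c1CCCN1CCCC1` has not yet been measured. It differs from compound 1 in one place: pyrrolidin-1-yl in place of 4-methylpiperazin-1-yl on a saturated chain carbon, three bonds along the chain from an aromatic carbon. The group that enters shares with the group that leaves a non-aromatic ring holding a nitrogen that counts as a hydrogen-bond acceptor, but it is smaller and lacks the second nitrogen.

Going by the values given here, only one measured step bears on this change, since it is the only one that replaces the same 4-methylpiperazin-1-yl group on the same chain carbon: a 4.6-fold higher number from compound 1 to compound 3 (0.67 log units; beyond the scatter), a modest rise. Among the compounds with values here, no measured pair shows what a smaller ring amine does, so the expectation rests on this single step, diluted because pyrrolidin-1-yl keeps a ring nitrogen that phenethyl does not. A small rise in the number, of the order of the scatter or a little beyond, is expected.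

For compound 4 the estimated value in this assay is 320 nM, with a range from 110 nM to 950 nM, which means an expected 1.8-fold higher number from compound 1 to compound 4 (0.25 log units; within the scatter).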

Compound 4, half-maximal effective concentration: 110 nM
Compound 4: middle estimate off by 2.9-fold (0.46 log units), on the high side; the measured number falls inside the stated range.
By their numbers in this assay, from the lowest: compounds 4 and 1 (each within the scatter of the next); then compound 3; then compound 2.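

In this assay, pyrrolidin-1-yl in place of 4-methylpiperazin-1-yl on a saturated chain carbon, three bonds along the chain from an aromatic carbon, leaves the number within the scatter (a 1.6-fold lower number from compound 1 to compound 4 (0.21 log units; within the scatter)), so at this position the five-membered ring with one nitrogen matches the six-membered ring with two. The same ring end also stands clearly apart from the other two groups: pyrrolidin-1-yl in place of phenethyl gives a modest step (a 7.5-fold lower number from compound 3 to compound 4 (0.88 log units; beyond the scatter)), and (pyrrolidin-1-yl)methyl in place of 1-hydroxy-1-methylethyl gives a large one (a 29-fold lower number from compound 2 to compound 4 (1.46 log units; beyond the scatter)). Across these four compounds, then, the two chain ends that carry a ring nitrogen sit together at the low end of the numbers, and no compound shown goes against this.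

Nothing available here explains why the numbers fall this way. Still open, from the compounds shown here alone, is whether a piperidin-1-yl ring, an open-chain amine such as dimethylamino, or a longer chain between the shared core and the ring would keep the number at this level.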